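The source may hold more compounds than are shown below. What is called first, only, known or untested is meant among the compounds shown, and "the series" means these compounds.

Compound 3 `CCCCCCc1cn(Cc2cc(=O)oc3cc(O)ccc23)nn1` is one of three close analogues built on a shared core. In a functional assay on A549 cells (Homo sapiens) for inhibition, read by MTT assay, with a stated time of 72 h (a higher number here means a weaker inhibitor, a lower number a stronger inhibitor), compound 3 gives 66200 nM. Compound 1 `O=c1cc(Cn2cc(CCO)nn2)c2ccc(O)cc2o1` gives 90300 nM, and compound 2 `CC(C)(C)c1cn(Cc2cc(=O)oc3cc(O)ccc23)nn1` gives 67600 nM. The steps among them are all small: a 1.3-fold lower number from compound 1 to compound 2 (0.13 log units; within the scatter), a 1.4-fold lower number from compound 1 to compound 3 (0.13 log units; within the scatter) and a 1.0-fold lower number from compound 2 to compound 3 (0.01 log units; within the scatter). Among the compounds with values here, compound 3 therefore sits among its neighbours, with no step to either of them beyond the scatter.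

Compound 4 `O=c1cc(Cn2cc(CCc3ccccc3)nn2)c2ccc(O)cc2o1` differs from compound 3 by phenyl in place of butyl on a saturated chain carbon, two bonds along the chain from an aromatic carbon. Within the data shown here, two measured steps bear on this position: the step from compound 1 to compound 3, a 1.4-fold lower number from compound 1 to compound 3 (0.13 log units; within the scatter), and the step from compound 2 to compound 3, a 1.0-fold lower number from compound 2 to compound 3 (0.01 log units; within the scatter), both changes of the group on the triazole and both within the scatter. On that basis no step beyond the scatter is expected in this assay, so a 1.1-fold lower number from compound 3 to compound 4 (0.04 log units; within the scatter) is the estimated change. Compound 4 is thus expected to give about 60000 nM, with a range from 25000 nM to 150000 nM.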

Compound 4, half-maximal inhibitory concentration: 24800 nM
Beside the measured number, compound 4's estimate is 2.4-fold (0.38 log units) above it, outside the stated range (below it).
By their numbers in this assay, from the lowest: compound 4; then compounds 3, 2 and 1 (each within the scatter of the next).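

In this assay, within the data shown here, phenyl in place of butyl on a saturated chain carbon, two bonds along the chain from an aromatic carbon, gives the first step at this position beyond the scatter (a 2.7-fold lower number from compound 3 to compound 4 (0.43 log units; beyond the scatter)). The phenethyl group of compound 4 also separates from the tert-butyl and 2-hydroxyethyl groups (a 2.7-fold lower number from compound 2 to compound 4 (0.44 log units; beyond the scatter); a 3.6-fold lower number from compound 1 to compound 4 (0.56 log units; beyond the scatter)), whereas those two groups and hexyl stayed within the scatter of one another, so this position does respond to the group it carries, if only modestly. No measurement shown here accounts for these steps.

The compounds shown leave open whether the step belongs to the phenyl ring itself or to its distance from the aromatic carbon, which a benzyl or 3-phenylpropyl group would test. They also leave open how cyclohexyl in place of phenyl, or an amine on the phenyl ring, would read.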